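Replacing a methylsulfonyl by methylsulfanyl in a shared core

A few compounds are considered here, and "the series" means these few. Any claim that something is new, unique, unknown or untested is made for them only; others in the source may bear on it.

Of the compounds shown here, three share one core and have been measured in a functional assay on CHO cells for agonist activity at Alpha-2C adrenergic receptor (Homo sapiens); on this read-out higher numbers stand for larger maximal responses and lower numbers for smaller maximal responses. Compound 1 `CSc1ccc(F)cc1NCC1=NCCN1` gives 97%, compound 2 `COc1ccc(SC)c(NCC2=NCCN2)c1` gives 74%, and compound 3 `CS(=O)(=O)c1ccc(Cl)cc1NCC1=NCCN1` gives 81%. Among these numbers compound 3 stands second highest: it is nearest to compound 2, whose number is lower by an amount within the scatter, and furthest from compound 1, whose number is higher by an amount beyond the scatter. Among the compounds with values here, the only single-point step measured so far is a number 23 percentage points lower from compound 1 to compound 2 (beyond the scatter).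

Compound 4 `CSc1ccc(Cl)cc1NCC1=NCCN1` has not yet been measured. It differs from compound 3 in one place: methylsulfanyl in place of methylsulfonyl on an aromatic carbon. Within the data shown here, no measured step concerns this exchange, so the step from compound 1 to compound 2 bears on it only in showing that a single change on this core can move the maximal response by a modest amount. Compound 1 carries the same methylsulfanyl group together with a fluoro group and gives 97%, which points upward rather than downward.

Compound 4 is therefore expected to give about 90% in this assay, most likely between 72% and 105%. This corresponds to an expected step of a number 9 percentage points higher from compound 3 to compound 4 (within the scatter), somewhat above the scatter but uncertain in size.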

Compound 4, largest response reached (reported as maximum), in percent of the reference or control that the assay uses: 92%
Estimate against measurement, compound 4: 2 percentage points below; the range from low to high includes it.
By their numbers in this assay, from the lowest: compounds 2 and 3 (each within the scatter of the next); then compounds 4 and 1 (each within the scatter of the next).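

At the aromatic carbon ortho to a group of 7 heavy atoms and para to a chloro group, the exchange of methylsulfonyl for methylsulfanyl now has a measured size in this assay as a number 11 percentage points higher from compound 3 to compound 4 (beyond the scatter) with the chloro group held constant, so this position affects the maximal response by a modest amount. With methylsulfanyl kept, the other substituent can also be read: chloro in place of methoxy gives a number 18 percentage points higher from compound 2 to compound 4 (beyond the scatter) and chloro in place of fluoro gives a number 5 percentage points lower from compound 1 to compound 4 (within the scatter) in the same assay, so the chloro and fluoro groups cannot be told apart here, while the methoxy group of compound 2 stands apart from both. Nothing available here offers an explanation for any of these steps.

From the compounds shown here alone, what remains open is whether the exchange of methylsulfonyl for methylsulfanyl has the same size when a fluoro or methoxy group takes the place of the chloro group, as the step is read with chloro alone. Also open, going by these compounds, is how an amine, a carboxylic acid or a longer chain such as ethylsulfanyl would fare at the position held by methylsulfanyl.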